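Cytotoxicity check on a fused bicyclic amide series

This account rests on a few compounds, and the source may have more. Where it says the series, first, only, none or still open, it means among the compounds named here.

Two analogues of the shared core have been run in an ADME assay on HepG2 cells (Homo sapiens) for cytotoxicity, read by resazurin assay, with a stated time of 48 h; a higher number here means that more compound is needed for the effect, a lower number that less compound is needed. Compound 1 `Cc1nc(C)c(C(=O)Nc2ccc(F)c(-c3nc4ncc(-c5cccnc5Cl)cn4n3)c2)o1` sits at the limit of the assay, with > 50000 nM reported rather than a number. Compound 2 `O=C(Nc1ccc(F)c(-c2nc3ncc(-c4cc(F)ccc4F)cc3[nH]2)c1)N1CCCC1` likewise returns only a limit, > 50000 nM. For the measured compounds named here, both values therefore rest on (the limit of > 50000 nM in this assay, at which 2 of the 2 values shown sit), and no step between them can be read.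

Compound 3 `O=C(Nc1ccc(F)c(-c2nc3ncc(-c4ccc(O)cc4)cc3[nH]2)c1)N1CCCC1` is not yet measured. Its change from compound 2 is 4-hydroxyphenyl in place of 2,5-difluorophenyl on an aromatic carbon. With both neighbours at the limit, no step beyond the scatter is expected: the estimate for compound 3 is 60000 nM (range 20000 nM to 200000 nM), a step that the limit leaves unreadable from compound 2 to compound 3 expected, most likely again reported as a limit.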

Compound 3, half-maximal effective concentration: > 50000 nM
Compound 3 gave a limit, no number (the forecaster's own chance of this, stated with the estimate: 80%); the middle value is on the limit's open side.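

Compound 2 and compound 3 both return only limits in this assay, so no step can be read between them: the limit of > 50000 nM in this assay, at which 3 of the 3 values shown sit.

The compounds shown leave open what concentration of any analogue of the shared core gives the half-maximal effect in this assay.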